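Working notes: expectation for compound 4 from compounds 1 to 3

The source may report more compounds than this note shows. Statements on the series, on what has been measured and on what is new or still open speak of the compounds shown alone.

Measured so far in a functional assay on NCI-H460 cells (Homo sapiens) for cytotoxicity, read by MTT assay, with a stated time of 72 h; a lower number here means a stronger inhibitor, a higher number a weaker inhibitor:
compound 1 `CC(C)c1[nH]cnc1/C=c1\[nH]c(=O)/c(=C/c2cccc(C(=O)c3ccc(F)cc3)c2)[nH]c1=O` — 3.2 nM
compound 2 `O=C(c1ccc(F)cc1)c1cccc(/C=c2\[nH]c(=O)/c(=C/c3nc[nH]c3C3CC3)[nH]c2=O)c1` — 2.8 nM
compound 3 `O=c1[nH]/c(=C\c2ccccn2)c(=O)[nH]/c1=C\c1cccc(Oc2ccc(F)cc2)c1` — 49.1 nM

Compounds 1 and 2 share one arm and differ only on the other; the step of a 1.1-fold lower number from compound 1 to compound 2 (0.06 log units; within the scatter) is the only measured one, and it lies within the scatter. Compound 3 carries a different arm on both sides and gives the highest of the three numbers: its gap to compound 1 and to compound 2 is well beyond the scatter, so compound 3 is the weakest of the measured set.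

Compound 4 `COCc1ccc(/C=c2\[nH]c(=O)/c(=C/c3cccc(Oc4ccc(F)cc4)c3)[nH]c2=O)o1` keeps the arm that compound 3 shares with nothing else measured and changes the other arm: 5-(methoxymethyl)furan-2-yl in place of pyridin-2-yl on a double-bonded chain carbon bound to an aromatic carbon. Within the data shown here, no measured step bears on this position; the only step known concerns a substituent on the other arm and was flat. The change is therefore unanchored, and the expectation rests on compound 3 alone, with no reason from the data to expect movement in either direction beyond the scatter. The step of a 1.2-fold higher number from compound 3 to compound 4 (0.09 log units; within the scatter) is expected to stay close to neutral, with wide uncertainty. For compound 4 the estimate in this assay is 60 nM, in the range 12 nM to 300 nM.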

Compound 4, half-maximal inhibitory concentration: 14 nM
Compound 4: the middle estimate sits 4.3-fold (0.63 log units) above what was measured, within the range that was stated.
By their numbers in this assay, from the lowest: compounds 2 and 1 (each within the scatter of the next); then compound 4; then compound 3.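

In this assay, among these compounds, a 3.5-fold lower number from compound 3 to compound 4 (0.54 log units; beyond the scatter) gives the first measured step at this position, and it is modest but beyond the scatter, whereas the only earlier step, a 1.1-fold lower number from compound 1 to compound 2 (0.06 log units; within the scatter), concerned the other arm and stayed within it. The position on a double-bonded chain carbon bound to an aromatic carbon therefore responds to its substituent, and a pyridin-2-yl group is not the only arm tolerated there: 5-(methoxymethyl)furan-2-yl gives the lower number. The change alters the ring and adds a chain at the same time, so this single step does not assign the shift to either part, and no supporting measurement bears on its cause.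

The compounds shown leave open whether the shift follows the five-membered aromatic ring or the methoxymethyl chain, a question that an unsubstituted furan-2-yl group, or a furan-2-yl group carrying an aminomethyl group or a carboxylic acid at that place, would address. Among the compounds shown here, also open is whether the same change gives a similar step when the other arm is the one carried by compound 1.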